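Taking the chloro group off compound 2

The compounds below may be only part of what the source reports. "The series", "measured", "known", "first", "only" and "open" are said of these compounds alone.

Values from a functional assay on B16 cells (Mus musculus) for inhibition, read by MTT assay, with a stated time of 24 h; a higher number here means a weaker inhibitor, a lower number a stronger inhibitor:
- compound 1 `O=[N+]([O-])c1cc(Cl)ccc1CNc1cc(C(F)(F)F)cc2[nH]ncc12`: > 20000 nM
- compound 2 `O=[N+]([O-])c1ccc(Cl)cc1CNc1cc(C(F)(F)F)cc2[nH]ncc12`: 11600 nM

The entry for compound 1 is a limit of the assay, not a number. For the measured compounds named here, compound 2 therefore holds the only true number so far, 11600 nM, and it sits on the weak side of the scale.

Compound 3 `O=[N+]([O-])c1ccccc1CNc1cc(C(F)(F)F)cc2[nH]ncc12` has hydrogen in place of chloro on an aromatic carbon of compound 2, para to a nitro group (hydrogen in place of chloro on an aromatic carbon).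

Going by the values given here, no measured step yet shows what this kind of change does. Only a small step is expected in this assay, towards weaker inhibition if it exceeds the scatter at all. Compound 3 is estimated at 14000 nM, with an expected range of 7000 nM to 28000 nM. The expected step is a 1.2-fold higher number from compound 2 to compound 3 (0.08 log units; within the scatter). A limit rather than a number remains a real possibility for compound 3.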

Compound 3, half-maximal inhibitory concentration: > 20000 nM
Compound 3: no number, only a limit; the forecaster's own chance of this, stated with the estimate: 30%; middle value at least 1.4-fold (0.15 log units) away from the limit.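

In this assay compound 3 gives > 20000 nM, which is a limit of the assay and not a number. Hydrogen in place of chloro on this aromatic carbon, para to a nitro group, gives an at least 1.7-fold higher number from compound 2 to compound 3 (0.23 log units; that floor lies within the scatter), so the change brings no gain in inhibition, while the true size of the step stays unknown and may or may not exceed the scatter. Compound 2 remains the only compound here with a true number, and the series sits almost entirely at the edge of what the assay can read: the limit of > 20000 nM in this assay, at which 2 of the 3 values shown sit.

The step between compound 1 and compound 3 cannot be read. On these data alone, whether an amine, a methoxy group or a carboxylic acid on this carbon would give a lower number than chloro remains open.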